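This account rests on a few compounds, and the source may have more. Where it says the series, first, only, none or still open, it means among the compounds named here.

Measured compounds:
compound 1 `FC(F)(F)c1ccc(CN2CCN(Cc3cc(-c4ccc(OCc5cccc(Cl)c5)cc4)on3)CC2)cc1`, in a functional assay on Mahlavu cells (Homo sapiens) for antiproliferative activity, read by sulforhodamine B assay, with a stated time of 72 h (a lower number here means a stronger inhibitor, a higher number a weaker inhibitor), compound 1 gives 4100 nM
compound 2 `COc1cc(COc2ccc(-c3cc(CN4CCN(Cc5ccc(C(F)(F)F)cc5)CC4)no3)cc2)cc(OC)c1`, in this assay compound 2 gives 4300 nM
compound 3 `N#Cc1cccc(COc2ccc(-c3cc(CN4CCN(c5ccc(C(F)(F)F)cc5)CC4)no3)cc2)c1`, in this assay compound 3 gives 2700 nM

Compound 3 holds the lowest of the three numbers, though its gaps to compound 1 and compound 2 both sit within the scatter, so no order among the three can be claimed. Going by the values given here, the only step among the measured pairs is a 1.0-fold higher number from compound 1 to compound 2 (0.02 log units; within the scatter); it changes the group on the saturated chain carbon bound to the aromatic oxygen and leaves the piperazine substituent untouched. Compound 4 `N#Cc1cccc(COc2ccc(-c3cc(CN4CCN(C(=O)C5CCCO5)CC4)no3)cc2)c1` differs from compound 3 by (oxolan-2-yl)carbonyl in place of 4-(trifluoromethyl)phenyl on an amine nitrogen in a ring. Among the compounds with values here, no measured step touches this position: compound 1 and compound 2 carry a benzyl-type group where compound 3 carries an aryl group, and their numbers lie within the scatter of compound 3, but no step for that pair is given. Within the data shown here, the expectation for compound 4 therefore rests on nothing more than the run of numbers so far, and a step of a 2.2-fold higher number from compound 3 to compound 4 (0.35 log units; beyond the scatter) is estimated, with wide uncertainty. Compound 4 is expected at 6000 nM, within 1800 nM to 20000 nM.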

Compound 4, half-maximal inhibitory concentration: 4100 nM
Estimate against measurement, compound 4: 1.5-fold (0.17 log units) above; measured number inside the range.
By their numbers in this assay, from the lowest: compounds 3, 1, 4 and 2 (each within the scatter of the next).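

Read in this assay the first step at the amine nitrogen in the ring is a 1.5-fold higher number from compound 3 to compound 4 (0.18 log units; within the scatter) for (oxolan-2-yl)carbonyl in place of 4-(trifluoromethyl)phenyl. This exchange takes away the six-membered aromatic ring of carbon only and its three fluorine atoms, and brings in a five-membered non-aromatic ring, a double bond outside aromatic rings and 2 hydrogen-bond acceptors, yet the step stays within the scatter, so the two groups cannot be told apart at this position. No supporting measurement bears on this result.

On these data alone, whether an acetyl group, a free amine or a carboxylic acid on a longer chain at this nitrogen would give a step beyond the scatter stays open. As far as these compounds go, with one step read here, it also remains open whether any group at this position separates from the others in this assay at all.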